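A few compounds are considered here, and "the series" means these few. Any claim that something is new, unique, unknown or untested is made for them only; others in the source may bear on it.

Measured compounds:
- compound 1, `CCOc1ccc2c(c1)C(c1c[nH]cn1)=CN(C)C(=O)[C@@H]2C`: 2.7
- compound 2, `CCOc1ccc2c(c1)C(c1cn(C)cn1)=CN(C)C(=O)[C@@H]2C`: 3.6
- compound 3, `C[C@H]1C(=O)N(C)C=C(c2cn[nH]c2)c2cc([C@H](O)CO)ccc21`: 0.8

In a physicochemical assay for lipophilicity, at pH 7.4 (a higher number here means a more lipophilic compound, a lower number a more polar compound), compound 1 gives 2.7. Among the measured compounds shown here, compound 2 differs from it by methyl in place of hydrogen on an aromatic nitrogen, and in this assay compound 2 gives 3.6, so the step of a number 0.90 log units higher from compound 1 to compound 2 (beyond the scatter) is the only measured example of this kind of change. Compound 3 sits on a different core; in this assay compound 3 gives 0.8, the lowest of the three numbers, with compound 1 and compound 2 both standing beyond the scatter above it. The difference between the core of compound 3 and the core of compound 1 is not broken down here.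

Compound 4, `C[C@H]1C(=O)N(C)C=C(c2cnn(C)c2)c2cc([C@H](O)CO)ccc21`, has not yet been measured in this assay. It differs from compound 3 by methyl in place of hydrogen on an aromatic nitrogen. For the measured compounds named here, this is the same kind of change as the one from compound 1 to compound 2, but not the same: in compound 4 the methyl enters on an aromatic nitrogen next to the ring nitrogen, whereas in compound 2 it enters two ring bonds from the ring nitrogen. The expectation rests on a single measured example, the step of a number 0.90 log units higher from compound 1 to compound 2 (beyond the scatter), and the changed surroundings leave its exact size open. For compound 4 a step of a number 0.70 log units higher from compound 3 to compound 4 (beyond the scatter) in this assay is expected, somewhat smaller than the measured one. The estimate for compound 4 is 1.5, expected to fall between 1.1 and 1.9.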

Compound 4, distribution coefficient: 1.3
The estimate for compound 4 lay 0.20 log units above the measured number, within the range that was stated.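

In this assay the change of methyl in place of hydrogen on an aromatic nitrogen now has two measured examples, and the number rises in both, with a number 0.50 log units higher from compound 3 to compound 4 (beyond the scatter) and, on the other core, a number 0.90 log units higher from compound 1 to compound 2 (beyond the scatter) as the earlier step. The direction therefore carried over between the two cores shown, but the size did not stay the same: the step on the core of compound 3 is the smaller as printed, and two examples set no rule for any further core. The pairs also differ in the ring that takes the methyl and in its place on that ring, so they do not separate the contributions of core, ring and place to the size of the step, and nothing available bears on a cause.

Left open is how 1-methyl-1H-pyrazol-4-yl itself reads on the core of compound 1, a comparison that would hold the ring constant while the core changes. Also open, on these data alone, is whether a longer chain such as ethyl on the same aromatic nitrogen, or a chain ending in an amine or a carboxylic acid, would move the number in the same direction in this assay on either core.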